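The compounds below may be only part of what the source reports. "The series", "measured", "known", "first", "only" and "open" are said of these compounds alone.

The step traced here goes from compound 2 to compound 3. Compound 2 has the structure `Cc1ccc(/C=N/NC(N)=S)c2ccccc12`. In a toxicity assay on THP-1 cells (Homo sapiens) for cytotoxicity, read by MTT assay, with a stated time of 72 h (a higher number here means that more compound is needed for the effect, a lower number that less compound is needed), compound 2 gives 32000 nM, and among the two compounds already measured in this assay this is the only entry that is an actual number. Among the compounds with values here, compound 1, with the structure `Cn1c(/C=N/N=C(/N)S)cc2ccccc21`, gives in this assay only a limit, > 200000 nM, and not a number. the limit of > 200000 nM in this assay, at which 1 of the 2 values shown sits, is the reason compound 2 stands alone as the one compound with a measured concentration in this assay. Compound 3, with the structure `CCOc1ccc(/C=N/NC(N)=S)c2ccccc12`, has not yet been measured. It differs from compound 2 in a single place: ethoxy in place of methyl on an aromatic carbon. Within the data shown here, no step between two measured compounds is available, so nothing here shows how such a change moves the read-out of this assay. With the rest of the structure untouched, the expected step from compound 2 to compound 3 is no change at the digits printed from compound 2 to compound 3 (within the scatter), no larger than the usual scatter in either direction. Compound 3 is therefore estimated at 32000 nM in this assay, with a range from 12000 nM to 90000 nM.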

Compound 3, half-maximal effective concentration: > 200000 nM
Compound 3: no number, only a limit; the forecaster's own chance of this, stated with the estimate: 15%; at least 6.2-fold (0.79 log units) between middle value and limit.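

Within the data shown here, replacing methyl with ethoxy on this aromatic carbon gives an at least 6.2-fold higher number from compound 2 to compound 3 (0.79 log units; beyond the scatter), the first step in this assay that can be read between two measured compounds. It shows that this one place on the shared core can change the read-out by more than the usual scatter, with more compound needed for the effect when ethoxy sits there than when methyl does. Compound 3 gives only a limit, > 200000 nM, and not a number, so the step has a known minimum but no known maximum: the limit of > 200000 nM in this assay, at which 2 of the 3 values shown sit.

The compounds shown cannot separate the oxygen of the ethoxy group from its two-carbon chain as the source of this step, a question that a methoxy group or an ethyl group on the same carbon could help to answer. Going by these compounds, how the read-out responds to a hydroxyl group, an amine, a chlorine atom or a longer alkoxy chain at this place also stays open, including whether any such group would give a lower number than compound 2 does.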